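A few compounds are considered here, and "the series" means these few. Any claim that something is new, unique, unknown or untested is made for them only; others in the source may bear on it.

Measured so far:

compound 1, `Cc1nc(-c2ccccc2)sc1COc1ccc2c(c1)OCC2CC(=O)O`: 54.8% in a functional assay on CHO cells for agonist activity at Free fatty acid receptor 1 (Homo sapiens), read by FLIPR and calcium flux, tested at 100 nM; a lower number here means a weaker effect, a higher number a stronger effect of the compound at the concentration tested
compound 2, `Cc1cc(COc2ccc3c(c2)OCC3CC(=O)O)nn1-c1ccccc1`: 0.98% in this assay

Compound 1 holds the higher of the two numbers; the value of compound 2 lies well below it, a gap beyond the usual scatter. Beyond this pair nothing is known, and no step between two measured compounds that differ in one place is available, so the effect of any single change must be projected from compound 1 alone.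

Compound 3, `Cc1cccc(-c2nc(C)c(COc3ccc4c(c3)OCC4CC(=O)O)s2)c1`, is the next to be measured. It differs from compound 1 in one place: methyl in place of hydrogen on an aromatic carbon. The group that enters is small, carries no donor or acceptor and no charge, and sits on the aromatic carbon of the six-membered ring of carbon only, meta to a large group.

Among the measured compounds shown here, with only compound 1 as a reference and no step of this kind on record, the expected step of a number 2.2 percentage points higher from compound 1 to compound 3 (within the scatter) in this assay is small, possibly none beyond the scatter, with no firm direction. Compound 3 is therefore estimated at 57%, with a range from 30% to 85%.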

Compound 3, a percentage reported as activity, at one concentration (the size of the read-out at that concentration, not a potency): 47.2%
Compound 3: the middle estimate sits 9.8 percentage points above what was measured; low and high end bracket the measured number.
By their numbers in this assay, from the lowest: compound 2; then compounds 3 and 1 (each within the scatter of the next).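

In this assay, the change from phenyl to 3-methylphenyl gives a number 7.6 percentage points lower from compound 1 to compound 3 (within the scatter), so methyl on this aromatic carbon of the six-membered ring of carbon only leaves the read-out indistinguishable from that of the unsubstituted phenyl. Among the compounds shown here, this is the first step between two compounds that differ in one place, and it shows that this ring can take a small added group without a change beyond the scatter. No measurement on hand bears on the reason for this result.

Open, on these data alone, is whether groups other than methyl at this place, such as ethyl, methoxy, trifluoromethyl, chlorine or an amine, would also leave the read-out unchanged. Because each compound is read at a single concentration, the step also leaves open how the potencies of compound 1 and compound 3 compare.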